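From Isopropyl to Methylsulfanyl: Expected Binding of Compound 4

The source may hold more compounds than are shown below. What is called first, only, known or untested is meant among the compounds shown, and "the series" means these compounds.

Of the compounds shown here, three built on one shared core have been measured in an assay on isolated protein for displacement of a labelled ligand from melanin-concentrating hormone receptor 1 (Homo sapiens); a lower number here means a stronger inhibitor, a higher number a weaker inhibitor. Compound 1 `CCCc1cc(N)c2cc(NC(=O)/C=C/c3ccc(C(C)(C)C)cc3)ccc2n1` gives 22 nM, compound 2 `CCCc1cc(N)c2cc(NC(=O)/C=C/c3ccc(CC)cc3)ccc2n1` gives 1.4 nM, and compound 3 `CCCc1cc(N)c2cc(NC(=O)/C=C/c3ccc(C(C)C)cc3)ccc2n1` gives 2.9 nM. Compound 3 therefore stands second highest of the three numbers, with compound 2 nearest to it and compound 1 furthest away. All measured steps exchange the group on the same aromatic carbon of the six-membered ring: a 16-fold lower number from compound 1 to compound 2 (1.20 log units; beyond the scatter), a 7.6-fold lower number from compound 1 to compound 3 (0.88 log units; beyond the scatter), and a 2.1-fold higher number from compound 2 to compound 3 (0.32 log units; beyond the scatter). Compound 4 `CCCc1cc(N)c2cc(NC(=O)/C=C/c3ccc(SC)cc3)ccc2n1` changes that same position once more: methylsulfanyl in place of isopropyl on an aromatic carbon. Within the data shown here, the three steps show that this position moves this assay considerably, and that the direction depends on which group sits there; none of the measured compounds carries a sulfur-bearing group, so the steps bound the likely size rather than fix the direction. Compound 4 is therefore estimated at 2 nM, within a range of 0.6 nM to 7 nM, which means an expected 1.5-fold lower number from compound 3 to compound 4 (0.16 log units; within the scatter) that may not exceed the scatter.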

Compound 4, half-maximal inhibitory concentration: 9 nM
Estimate against measurement, compound 4: 4.5-fold (0.65 log units) below; measured number above the stated range.
By their numbers in this assay, from the lowest: compound 2; then compound 3; then compound 4; then compound 1.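

In this assay, among these compounds, exchanging isopropyl for methylsulfanyl gives a 3.1-fold higher number from compound 3 to compound 4 (0.49 log units; beyond the scatter), exchanging ethyl for it gives a 6.4-fold higher number from compound 2 to compound 4 (0.81 log units; beyond the scatter), and exchanging tert-butyl for it gives a 2.4-fold lower number from compound 1 to compound 4 (0.39 log units; beyond the scatter), so the only sulfur-bearing group here falls inside the span set by the three carbon-only groups. Among those three, the number rises from ethyl through isopropyl to tert-butyl, but compound 4 goes against any reading by heavy-atom count alone, since methylsulfanyl has fewer heavy atoms than isopropyl and yet compound 4 has the higher number. No measurement is available that accounts for this result.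

The compounds shown leave open whether the sulfur atom itself matters, which methoxy, with oxygen in its place, could test. They also leave open how a longer chain on the sulfur, as in ethylsulfanyl, would read in this assay.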